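The source may report more compounds than this note shows. Statements on the series, on what has been measured and on what is new or still open speak of the compounds shown alone.

Of the compounds shown here, three sharing one core have been measured in an assay on cells for displacement of a labelled ligand from transmembrane domain-containing protein TMIGD3 (Homo sapiens), read by scintillation counting, with a stated time of 120 min; on this read-out higher numbers stand for weaker inhibition and lower numbers for stronger inhibition. Compound 1, `O=C(c1ccccc1)N(C(=O)c1ccccc1)c1nccn2cc(-c3ccccc3)nc12`, gives 64 nM in this assay. Compound 2, `COc1ccc(C(=O)Nc2nccn3cc(-c4ccccc4)nc23)cc1`, gives 162 nM in this assay. Compound 3, `Cc1ccc(C(=O)Nc2nc(-c3ccccc3)cn3cc(-c4ccccc4)nc23)cc1`, gives 223 nM in this assay, the highest number of the three. Compound 3 and compound 2 lie within the usual scatter of each other, so nothing can be said about their order. Compound 1, by contrast, gives a number that sits beyond the scatter below that of compound 3, so among these three compound 1 shows stronger inhibition than compound 3.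

The next step leads from compound 3 to compound 4, `O=C(Nc1nc(-c2ccccc2)cn2cc(-c3ccccc3)nc12)c1cccs1`, which has not yet been measured in this assay. The change is thiophen-2-yl in place of 4-methylphenyl on a carbonyl carbon. The aryl amide at that position is the only part of the molecule that moves; the rest of compound 3 is kept unchanged.

Within the data shown here, no measured pair in this set shows what such an exchange does, so the expectation rests only on the numbers already in hand. Compound 4 is expected to remain close to compound 3, and the step from compound 3 to compound 4 is estimated as a 1.1-fold lower number from compound 3 to compound 4 (0.05 log units; within the scatter), not clearly beyond the scatter in either direction. Compound 4 is therefore estimated at 200 nM in this assay, with a range from 80 nM to 500 nM.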

Compound 4, inhibition constant: 185 nM
Estimate against measurement, compound 4: 1.1-fold (0.03 log units) above; measured number inside the range.
By their numbers in this assay, from the lowest: compound 1; then compounds 2, 4 and 3 (each within the scatter of the next).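

Thiophen-2-yl in place of 4-methylphenyl on a carbonyl carbon gives a 1.2-fold lower number from compound 3 to compound 4 (0.08 log units; within the scatter) in this assay and is the only step in this set that can be read between compounds differing in one place. At this position of the compound 3 scaffold, a six-membered aromatic ring of carbon only and a five-membered aromatic ring with a hetero atom therefore cannot be told apart, even though the entering group is smaller and brings a hydrogen-bond acceptor that the leaving group lacks. No measurement offered here accounts for this outcome.

As far as these compounds go, both groups in this step are aromatic rings, so it remains open what happens on the same carbonyl carbon with a cyclohexyl ring, a longer alkyl chain, an aminomethyl group or a carboxylic acid. From the compounds shown here alone, it also remains open whether thiophen-2-yl would give a similar result on the core of compound 2, and whether a ring with other hetero atoms, such as pyridine or furan, would stay within the scatter of compound 3.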